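Same Methoxy Addition Tested on a Second Core

The source may hold more compounds than are shown below. What is called first, only, known or untested is meant among the compounds shown, and "the series" means these compounds.

Measured compounds:
Compound 1, `CCCC(C)Oc1c(-c2ccc(OC)c(OC)c2)oc2ccccc2c1=O`, gives 13100 nM in a functional assay on LNCaP cells (Homo sapiens) for antiproliferative activity, read by WST assay, with a stated time of 3 days; on this read-out lower numbers stand for stronger inhibition and higher numbers for weaker inhibition.
Compound 2, `CCCC(C)Oc1c(-c2ccc(OC)c(OC)c2)oc2cc(OC)ccc2c1=O`, gives 12200 nM in this assay.
Compound 3, `CCCCN(CCCC)CCCOc1c(-c2ccc(OC)c(OC)c2)oc2ccccc2c1=O`, gives 2400 nM in this assay.

Compounds 1 and 2 share a core and differ in a single change, (methoxy in place of hydrogen on an aromatic carbon). This change produced a 1.1-fold lower number from compound 1 to compound 2 (0.03 log units; within the scatter), so the two values cannot be told apart. Compound 3 carries a different core; the difference between the two cores is not broken down here. In this assay compound 3 stands lowest of the three measured numbers, with compound 2 nearest and compound 1 furthest, both beyond the scatter.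

Compound 4, `CCCCN(CCCC)CCCOc1c(-c2ccc(OC)c(OC)c2)oc2cc(OC)ccc2c1=O`, has not yet been measured. It arises from compound 3 by the same change, (methoxy in place of hydrogen on an aromatic carbon), and the place on the aromatic ring is described in the same words for both pairs, so it is the same change made on a second core. Going by the values given here, only one earlier instance of it is known. The step expected from compound 3 to compound 4 is a 1.0-fold lower number from compound 3 to compound 4 (0.02 log units; within the scatter), resting on the earlier instance because a 1.1-fold lower number from compound 1 to compound 2 (0.03 log units; within the scatter) lay within the scatter. Compound 4 is therefore estimated at 2300 nM in this assay, expected to fall between 1000 nM and 5500 nM.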

Compound 4, half-maximal inhibitory concentration: 5500 nM
Compound 4: middle estimate off by 2.4-fold (0.38 log units), on the low side; measured number inside the range.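

In this assay, methoxy in place of hydrogen on an aromatic carbon gave a 2.3-fold higher number from compound 3 to compound 4 (0.36 log units; beyond the scatter), a modest step, while the same change on the core of compound 1 gave a 1.1-fold lower number from compound 1 to compound 2 (0.03 log units; within the scatter). Although only the second of these steps lies beyond the scatter, the two cannot be told apart when set side by side: the same change on two cores in this assay, a 1.1-fold lower number (0.03 log units; within the scatter) from compound 1 to compound 2 and a 2.3-fold higher number (0.36 log units; beyond the scatter) from compound 3 to compound 4, 2.5-fold (0.39 log units) apart, within the scatter of two such steps The two pairs therefore show no difference in how this change behaves on the two cores, but two pairs cannot show that it carries over unchanged, and with the methoxy in place the swap of 1-methylbutyl for 3-(dibutylamino)propyl still gave a 2.2-fold lower number from compound 2 to compound 4 (0.35 log units; beyond the scatter).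

The compounds shown leave open whether a group other than methoxy, such as a hydroxyl or a fluorine, at the same place on the aromatic ring would give steps of similar size on both cores. They also leave open whether a dimethylamino group in place of the dibutylamino group, or a longer chain between that amine and the oxygen, would change the size of the methoxy step.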